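Thiazol-2-yl in place of pyridin-3-yl: expected maximal response

A few compounds are considered here, and "the series" means these few. Any claim that something is new, unique, unknown or untested is made for them only; others in the source may bear on it.

Measured compounds:
compound 1 `c1cncc(-c2ccccc2OCC2=NCCN2)c1`: 109%
compound 2 `c1csc(-c2ccccc2OCC2=NCCN2)c1`: 101%
compound 3 `c1ccc(-c2ncc[nH]2)c(OCC2=NCCN2)c1`: 122%

In a functional assay with Alpha-1A adrenergic receptor (Homo sapiens) as the target, read by calcium flux (on this read-out higher numbers stand for larger maximal responses and lower numbers for smaller maximal responses), compound 1 gives 109%, the second highest of the three numbers; compound 2 sits nearest to it, compound 3 furthest. The two measured steps away from compound 1 point in different directions: a number 8 percentage points lower from compound 1 to compound 2 (within the scatter) and a number 13 percentage points higher from compound 1 to compound 3 (beyond the scatter). Between the two five-membered rings the step is a number 21 percentage points higher from compound 2 to compound 3 (beyond the scatter).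

Compound 4 `c1ccc(-c2nccs2)c(OCC2=NCCN2)c1` is not yet measured. It differs from compound 1 in one place: 1,3-thiazol-2-yl in place of pyridin-3-yl on an aromatic carbon. The entering ring shares the sulfur of thiophen-2-yl in compound 2 and the two hetero atoms of 1H-imidazol-2-yl in compound 3. The steps from compound 1 to those two compounds are the ones that bear on this change; one lay within the scatter and one was a modest gain. Nothing in the data separates the two cases for the new ring, so the expectation for compound 4 is a step of a number 1 percentage points higher from compound 1 to compound 4 (within the scatter), most likely within the scatter of compound 1. For compound 4 the estimated value in this assay is 110%, with a range from 95% to 126%.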

Compound 4, largest response reached (reported as maximum), in percent of the reference or control that the assay uses: 102%
Compound 4: middle estimate off by 8 percentage points, on the high side, within the range that was stated.
By their numbers in this assay, from the lowest: compounds 2, 4 and 1 (each within the scatter of the next); then compound 3.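

In this assay, 1,3-thiazol-2-yl on this aromatic carbon gives no separation from pyridin-3-yl, with a number 7 percentage points lower from compound 1 to compound 4 (within the scatter), and none from thiophen-2-yl, with a number 1 percentage points higher from compound 2 to compound 4 (within the scatter), so two five-membered rings of different hetero atom content and the six-membered ring all lie close together here. The higher response of compound 3 does not carry over to the new ring, with a number 20 percentage points lower from compound 3 to compound 4 (beyond the scatter), which shows that a second ring hetero atom alone is not enough for that gain: compound 4 and compound 3 both have two, and among these compounds only compound 3 has a ring nitrogen with its hydrogen where compound 4 has sulfur. Nothing available explains why these two rings part in this assay.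

Going by these compounds, whether the nitrogen hydrogen of compound 3, at 122%, or some other feature of that ring goes with the higher response remains open, and 1-methylimidazol-2-yl and oxazol-2-yl would be the direct comparisons. The compounds shown also leave open how an open-chain group such as an aminomethyl or a carboxylic acid would fare on this carbon, and maximal response alone says nothing about potency.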